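Bromoacrylamide thiazolidinediones: a benzyl substituent swap

A few compounds are considered here, and "the series" means these few. Any claim that something is new, unique, unknown or untested is made for them only; others in the source may bear on it.

Compound 1 `CC(C)(C)c1ccc(CN2C(=O)S/C(=C\c3ccc(N)cc3)C2=O)cc1`: 53000 nM
Compound 2 `C=C(Br)C(=O)Nc1ccc(/C=C2\SC(=O)N(Cc3cccc(F)c3)C2=O)cc1`: 5900 nM

In a functional assay on HeLa cells (Homo sapiens) for cytotoxicity, read by cell counting, with a stated time of 4 days (a lower number here means a stronger inhibitor, a higher number a weaker inhibitor), compound 1 gives 53000 nM, while compound 2 gives 5900 nM. Of the two measured compounds, compound 2 stands lowest, and its gap to compound 1 lies beyond the scatter. Compound 3 `C=C(Br)C(=O)Nc1ccc(/C=C2\SC(=O)N(Cc3ccc(C(F)(F)F)cc3)C2=O)cc1` has not yet been tested. It differs from compound 2 in one place: 4-(trifluoromethyl)phenyl in place of 3-fluorophenyl on a saturated chain carbon bound to an amide-type nitrogen in a ring. For the measured compounds named here, no measured pair isolates this kind of swap, so the expectation rests on compound 2 alone. Because compound 2 gives 5900 nM in this assay and the bromoacrylamide portion is kept unchanged, compound 3 is expected to land near it, with a step of a 1.0-fold higher number from compound 2 to compound 3 (0.01 log units; within the scatter) that is expected to stay within the scatter. Compound 3 is therefore estimated at 6000 nM, within a range from 2000 nM to 20000 nM.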

Compound 3, half-maximal inhibitory concentration: 13000 nM
For compound 3 the middle estimate is 2.2-fold (0.34 log units) below the measured one; the range from low to high includes it.
By their numbers in this assay, from the lowest: compound 2; then compound 3; then compound 1.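

With the bromoacrylamide portion held constant, the swap of 3-fluorophenyl for 4-(trifluoromethyl)phenyl on a saturated chain carbon bound to an amide-type nitrogen in a ring gives, in this assay, a 2.2-fold higher number from compound 2 to compound 3 (0.34 log units; beyond the scatter). For the compounds shown here, this is the first sign that this position is not indifferent to its substituent, though the step is modest and the weaker number belongs to the larger group. Nothing measured here accounts for the step.

As far as these compounds go, in this single pair, the kind of substituent and its location on the phenyl ring change together, so it remains open which of the two matters, and 4-fluorophenyl or 3-(trifluoromethyl)phenyl would separate them. From the compounds shown here alone, it also remains open how the position would respond to an unsubstituted phenyl, or to an amine or a carboxylic acid on that ring.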